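The source may report more compounds than this note shows. Statements on the series, on what has been measured and on what is new or still open speak of the compounds shown alone.

Working notes on the series. Three compounds around one shared core carry measured numbers. Compound 1 `CC(C)CCCc1nc(O)cc(O)n1` gives, in a functional assay on HEK293 cells for agonist activity at G-protein coupled receptor 84 (Homo sapiens), read by calcium flux (a lower number here means a smaller maximal response, a higher number a larger maximal response), 85.6%. Compound 2 `CCCCCCCCCc1nc(O)cc(O)n1` gives in this assay 84.1%, and compound 3 `CCCCCCCCNc1nc(O)cc(O)n1` gives in this assay 91.8%. Compound 1 holds the second highest of the three numbers, but its gap to compound 2 and its gap to compound 3 both lie within the scatter, so the three numbers cannot be told apart.

The next compound, compound 4 `CCCCCc1nc(O)cc(O)n1`, is compound 1 with one change: hydrogen in place of methyl on a saturated chain carbon bound to two saturated chain carbons. The saturated chain is shortened at its branched end, isobutyl to propyl, isopropyl to ethyl, with hydrogen in place of methyl.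

For the measured compounds named here, no step between two measured compounds is available for this change. What the series does show is that compound 1 and compound 2, which differ only in their saturated chain, give numbers within the scatter of each other. On that basis the step in this assay is expected to be small, at most a slight drop, and a number 5.6 percentage points lower from compound 1 to compound 4 (within the scatter) is the estimated size of it. Compound 4 is therefore expected to reach about 80% in this assay, within a range from 64% to 93%.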

Compound 4, largest response reached (reported as percent of maximum), in percent of the reference or control that the assay uses: 84.9%
Estimate against measurement, compound 4: 4.9 percentage points below; low and high end bracket the measured number.
By their numbers in this assay, from the lowest: compounds 2, 4, 1 and 3 (each within the scatter of the next).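

In this assay, for the compounds shown here, taking away the methyl on a saturated chain carbon bound to two saturated chain carbons, isobutyl to propyl, gives a number 0.7 percentage points lower from compound 1 to compound 4 (within the scatter), the first direct reading of this change, and the branch leaves no mark on the maximal response that can be told from the scatter. Hydrogen in place of butyl on a saturated chain carbon, five bonds along the chain from an aromatic carbon, gives a number 0.8 percentage points higher from compound 2 to compound 4 (within the scatter), so in this assay this large cut in the unbranched chain cannot be told from the scatter either, and the branched and unbranched chains shown here give no separable responses. No measurement is at hand that would account for these small steps.

Going by these compounds alone, still open is whether the response stays this level with a much shorter chain such as methyl, or with a still longer chain than the one in compound 2. Equally open, as far as these compounds go, is what a carboxylic acid or a hydroxyl at the chain end, or a phenyl ring in place of the chain, would do to the response.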